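This account rests on a few compounds, and the source may have more. Where it says the series, first, only, none or still open, it means among the compounds named here.

In a functional assay on G-361 cells (Homo sapiens) for inhibition, with a stated time of 72 h (on this read-out higher numbers stand for weaker inhibition and lower numbers for stronger inhibition), compound 1 `NC1CCC(Nc2nc(NCc3ccc(Br)cc3)c3ncn(C4CCCC4)c3n2)CC1` gives 1480 nM, compound 2 `NC1CCC(Nc2nc(NCc3ccc(-c4ccco4)cc3)c3ncn(C4CCCC4)c3n2)CC1` gives 164 nM, and compound 3 `NC1CCC(Nc2nc(NCc3ccc(-c4cccc(F)c4)nc3)c3ncn(C4CCCC4)c3n2)CC1` gives 49 nM, the lowest of the three numbers. Compound 4 `NC1CCC(Nc2nc(NCc3ccc(-c4ccco4)nc3)c3ncn(C4CCCC4)c3n2)CC1` remains unmeasured. It differs from compound 3 by furan-2-yl in place of 3-fluorophenyl on an aromatic carbon, next to the ring nitrogen and para to a large group: furan-2-yl in place of 3-fluorophenyl on an aromatic carbon. Within the data shown here, the only measured step involving furan-2-yl is a 9.0-fold lower number from compound 1 to compound 2 (0.96 log units; beyond the scatter), which is beyond the scatter. That step replaces bromo, so it does not size this exchange directly. No step beyond the scatter is therefore expected in this assay, and the estimated step is a 1.4-fold higher number from compound 3 to compound 4 (0.15 log units; within the scatter). For compound 4 the estimated value is 70 nM, with an expected range of 25 nM to 200 nM.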

Compound 4, half-maximal inhibitory concentration: 97 nM
For compound 4 the middle estimate is 1.4-fold (0.14 log units) below the measured one, and the stated range covers the measured number.
By their numbers in this assay, from the lowest: compounds 3, 4 and 2 (each within the scatter of the next, the first and the last beyond it); then compound 1.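

In this assay the carbon next to the ring nitrogen accepts furan-2-yl in place of 3-fluorophenyl, with a 2.0-fold higher number from compound 3 to compound 4 (0.30 log units; within the scatter) as the step, which lies within the scatter. Setting 6-(furan-2-yl)pyridin-3-yl in place of 4-(furan-2-yl)phenyl gives a 1.7-fold lower number from compound 2 to compound 4 (0.23 log units; within the scatter) as another step within the scatter, whereas a 15-fold lower number from compound 1 to compound 4 (1.18 log units; beyond the scatter) remains a large step beyond it. Nothing available gives a cause for these steps. The compounds shown leave open whether an amine or a carboxylic acid at this carbon would stay within the scatter of these two aromatic rings.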